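Methoxy in place of hydroxy on the shared core

The compounds below may be only part of what the source reports. "The series", "measured", "known", "first", "only" and "open" are said of these compounds alone.

Compound 2 `Oc1ccc2nc(-c3ccccc3)cc(O)c2c1` gives 7.75 ug/mL in a functional assay on HCT-8 cells (Homo sapiens) for cytotoxicity; on this read-out lower numbers stand for an effect already at smaller amounts and higher numbers for an effect only at larger amounts of compound. Compound 1 `Oc1cc(-c2ccccc2)nc2c(O)cccc12` returns only the assay limit, > 10 ug/mL, as described by the limit of > 10 ug/mL in this assay, at which 1 of the 3 values shown sits. Compound 3 `Oc1cc(-c2ccccc2)nc2c(F)cccc12` gives 0.04 ug/mL. Of the two numbered values, compound 2 stands highest; compound 3 lies far below it, beyond the scatter. For the measured compounds named here, the single measured step, an at least 250-fold lower number from compound 1 to compound 3 (2.39 log units; beyond the scatter), concerns fluoro in place of hydroxy at another place on the core and does not touch the oxygen changed here. Compound 4 `COc1ccc2nc(-c3ccccc3)cc(O)c2c1` differs from compound 2 by methyl in place of hydrogen on an oxygen on an aromatic ring. Going by the values given here, no measured step covers this exchange, so no shift beyond the scatter is expected, and the step of a 1.0-fold higher number from compound 2 to compound 4 (0.01 log units; within the scatter) is the estimated outcome. Compound 4 is expected at 8 ug/mL, within 3 ug/mL to 20 ug/mL.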

Compound 4, half-maximal effective concentration: 1 ug/mL
Compound 4: the middle estimate sits 8.0-fold (0.90 log units) above what was measured, and the stated range ends above it.
By their numbers in this assay, from the lowest: compound 3; then compound 4; then compound 2. At a limit, above all of these: compound 1.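

Hydroxy to methoxy at this oxygen on an aromatic ring is not a silent change in this assay: methyl in place of hydrogen gives a 7.8-fold lower number from compound 2 to compound 4 (0.89 log units; beyond the scatter). This is the first step shown at this place, and it runs toward the lower number, so the hydrogen on this oxygen is not required for the effect on these cells.

Going by these compounds, whether a longer chain such as ethoxy, or an amine in place of the oxygen, would move the number further stays open. Nothing shown bears on the reason for this step.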